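From Ethoxy to an Aminomethyl-Oxetane Ether

The compounds below may be only part of what the source reports. "The series", "measured", "known", "first", "only" and "open" are said of these compounds alone.

Going by the values given here, compound 3 `CCOc1nc(-c2ccc(NS(=O)(=O)c3cc(Cl)ccc3F)cc2)nc2[nH]nc(C)c12` is the only one of the three compounds with an actual number in an assay for inhibition of serine/threonine-protein kinase Sgk1 (Homo sapiens), with stated times of 30 min and 60 min, in the presence of a further agent that is not named here; a lower number here means a stronger inhibitor, a higher number a weaker inhibitor: compound 3 gives 183 nM. Compound 1 `O=C(N[C@@H]1CCNC1)c1cc(-c2ccc(NS(=O)(=O)c3cccc(Cl)c3Cl)cc2)nc2[nH]ncc12` reaches only a limit of this assay, < 1 nM. Compound 2 `NCCNC(=O)c1cc(-c2ccc(NS(=O)(=O)c3cccc(Cl)c3Cl)cc2)nc2[nH]ncc12` likewise reaches only a limit, < 1 nM. The step that the two limits leave unreadable from compound 1 to compound 2 is accordingly unreadable, which follows from the limit of < 1 nM in this assay, at which 2 of the 3 values shown sit. Compound 4 `Cc1n[nH]c2nc(-c3ccc(NS(=O)(=O)c4cc(Cl)ccc4F)cc3)nc(OCC3(CN)COC3)c12` differs from compound 3 by 3-(aminomethyl)oxetan-3-yl in place of methyl on a saturated chain carbon bound to an oxygen on an aromatic ring. Among the compounds with values here, none of the measured steps touches this place, so no measured step indicates a direction or size for the change. A step within the usual scatter, or at most a modest gain, is expected, a 2.3-fold lower number from compound 3 to compound 4 (0.36 log units; beyond the scatter). Compound 4 is therefore estimated at 80 nM, within a range of 20 nM to 400 nM.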

Compound 4, half-maximal inhibitory concentration: 1 nM
Compound 4: middle estimate off by 80-fold (1.90 log units), on the high side; the whole stated range lies above it.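

In this assay, ethoxy giving way to (3-(aminomethyl)oxetan-3-yl)methoxy produces a 180-fold lower number from compound 3 to compound 4 (2.26 log units; beyond the scatter) and shows that this place, on a saturated chain carbon bound to an oxygen on an aromatic ring, takes a much larger group and responds strongly to it. Going by these compounds alone, the earlier compounds gave no reading of this place, and their one step cannot be read. Compound 4 now sits at the edge of what the assay reads: the limit of < 1 nM in this assay, at which 2 of the 4 values shown sit.

The compounds shown leave open whether the gain belongs to the amine or to the oxetane ring. A plain 2-aminoethoxy chain, or a hydroxymethyl group in place of the aminomethyl on the oxetane, would separate the two.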